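Adding a Third Methoxy Group to a Cytotoxicity Series

The compounds below may be only part of what the source reports. "The series", "measured", "known", "first", "only" and "open" are said of these compounds alone.

Four related compounds share one core. Compound 1 `COc1cc(/C(Cl)=C/C=C(\C#N)C(=O)c2c[nH]c3ccccc23)cc(OC)c1OC` carries three methoxy groups on its pendant aromatic ring, and in an ADME assay on Vero cells (Chlorocebus sabaeus) for cytotoxicity, read by sulforhodamine B assay, with a stated time of 48 h (on this read-out lower numbers stand for stronger inhibition of growth and higher numbers for weaker inhibition of growth), compound 1 gives 16200 nM. Compound 2 `COc1ccc2[nH]cc(C(=O)/C(C#N)=C/C=C(\Cl)c3ccc(OC)c(OC)c3)c2c1` and compound 3 `COc1ccc2[nH]cc(C(=O)/C(C#N)=C/C=C(\Cl)c3ccc(Br)cc3)c2c1` were also tested in this assay, but for neither was a numerical result reported: compound 2 gives "not determined" (no result reported). Likewise compound 3 gives "not determined" (no result reported), so compound 2 stands without any number on this read-out. Compound 4 `COc1ccc2[nH]cc(C(=O)/C(C#N)=C/C=C(\Cl)c3cc(OC)c(OC)c(OC)c3)c2c1` is the next step: it differs from compound 2 by methoxy in place of hydrogen on an aromatic carbon, giving it the same three-methoxy pattern seen in compound 1. Among the measured compounds shown here, with no measured step available, no direction beyond the scatter can be predicted for this change. Compound 4 is expected to give about 15000 nM in this assay, within a range from 5000 nM to 45000 nM, because compound 1 gives 16200 nM with the same pendant ring.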

Compound 4, concentration for 50% growth inhibition: 9500 nM
The estimate for compound 4 lay 1.6-fold (0.20 log units) above the measured number; low and high end bracket the measured number.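

Among the compounds shown here, the one step that can be read is a 1.7-fold lower number from compound 1 to compound 4 (0.23 log units; within the scatter): with the same three-methoxy pendant ring, a methoxy group in place of hydrogen on an aromatic carbon of the shared core gives two compounds that cannot be told apart on this read-out. The step from compound 2 to compound 4 cannot be read, since compound 2 has no number. Nothing shown here offers an explanation for this result. Still open, as far as these compounds go, is whether a larger or charged group at that core position, such as an amine or a carboxylic acid, would move the number beyond the scatter.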